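A Fluorophenyl Swap Among Compounds Held at a Limit

The compounds below may be only part of what the source reports. "The series", "measured", "known", "first", "only" and "open" are said of these compounds alone.

Values so far in an ADME assay on MCF-10A cells (Homo sapiens) for inhibition, with a stated time of 48 h (a lower number here means a stronger inhibitor, a higher number a weaker inhibitor), for the two measured compounds:
Compound 1 (`O=C(Nc1ccc(Cl)cc1)N1CCC[C@H]1c1nc(-c2ccccc2Cl)no1`): > 50000 nM
Compound 2 (`O=C(Nc1ccc(Cl)cc1)N1CCC[C@H]1c1nc(-c2ccccc2Br)no1`): > 50000 nM

In this assay compound 2 has only a limit (> 50000 nM) and no number. The record so far amounts to the limit of > 50000 nM in this assay, at which 2 of the 2 values shown sit, and nothing more.

The next compound, compound 3 (`O=C(Nc1ccc(Cl)cc1)N1CCC[C@H]1c1nc(-c2cccc(F)c2)no1`), carries 3-fluorophenyl in place of 2-bromophenyl on an aromatic carbon of a five-membered aromatic ring with 2 nitrogen and 1 oxygen (3-fluorophenyl in place of 2-bromophenyl on an aromatic carbon). Among the compounds with values here, only one measured step bears on this change, and only loosely. That step, a step that the two limits leave unreadable from compound 1 to compound 2, put bromo in place of chloro on an aromatic carbon, and it offers no size to carry over.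

No readable shift is therefore expected in this assay in either direction, and compound 3 will quite likely return a limit as well. The expected change is a number no higher from compound 2 to compound 3 (the limit leaves the size open) in this estimate. For compound 3 the estimated value is 50000 nM with an expected range from 20000 nM to 100000 nM.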

Compound 3, half-maximal inhibitory concentration: > 50000 nM
Compound 3: a limit, no number; the forecaster's own chance of this, stated with the estimate: 80%; the middle value sits exactly at the limit.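

In this assay, within the data shown here, compound 3 gives > 50000 nM, which is a limit and not a number, so no step among compound 1, compound 2 and compound 3 can be read. The record now stands at a single shared value: the limit of > 50000 nM in this assay, at which 3 of the 3 values shown sit.

The compounds shown leave open how far apart these three lie in this assay, and whether any change to the shared core would give a readable number.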